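Swapping vinyl for prop-1-en-1-yl on an antiproliferative amide

This account rests on a few compounds, and the source may have more. Where it says the series, first, only, none or still open, it means among the compounds named here.

Measured so far in a functional assay on HeLa cells (Homo sapiens) for antiproliferative activity, read by MTT assay, with a stated time of 72 h; a lower number here means a stronger inhibitor, a higher number a weaker inhibitor:
- Compound 1 `C/C=C/C(=O)Nc1cccc(Oc2nc(Nc3ccn(C)n3)nc3c2CSCC3)c1`: > 50000 nM, which is a limit of the assay and not a number.
- Compound 2 `C=CC(=O)Nc1cccc(Oc2nc(Nc3cccc(OC)c3)nc3c2CSCC3)c1`: 28900 nM

Within the data shown here, compound 2 holds the only true number in this small set, since the other value is a limit. Among the measured compounds shown here, nothing yet shows how a single structural change moves the result, because no two measured compounds differ in just one place.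

Compound 3 `C/C=C/C(=O)Nc1cccc(Oc2nc(Nc3cccc(OC)c3)nc3c2CSCC3)c1` has not been measured. It differs from compound 2 in one place: prop-1-en-1-yl in place of vinyl on a carbonyl carbon. In plain words, prop-1-en-1-yl stands in place of vinyl on a carbonyl carbon.

The nearest guide is compound 1, which also carries prop-1-en-1-yl. Compound 1 reads > 50000 nM, and this is only a limit. That hint points weakly towards a higher number, so a modest weakening is expected in this assay, and it may not clear the usual scatter. The expected change is a 1.4-fold higher number from compound 2 to compound 3 (0.14 log units; within the scatter). The estimated value for compound 3 is 40000 nM, with an expected range from 20000 nM to 75000 nM.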

Compound 3, half-maximal inhibitory concentration: 13800 nM
Beside the measured number, compound 3's estimate is 2.9-fold (0.46 log units) above it, outside the stated range (below it).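

Among these compounds, this is the first comparison in which only the group on the carbonyl carbon changes, and in this assay prop-1-en-1-yl in place of vinyl gives a 2.1-fold lower number from compound 2 to compound 3 (0.32 log units; beyond the scatter). The added carbon is therefore tolerated at this position and, in this one pair, goes with a modest gain rather than a loss. With prop-1-en-1-yl held fixed, 3-methoxyphenyl in place of 1-methyl-1H-pyrazol-3-yl on the nitrogen gives an at least 3.6-fold lower number from compound 1 to compound 3 (0.55 log units; beyond the scatter), so the weak reading of compound 1 cannot be put down to prop-1-en-1-yl alone, and the true size of this step remains unknown, as compound 1 stands at a limit of the assay and not at a number: the limit of > 50000 nM in this assay, at which 1 of the 3 values shown sits.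

The compounds shown leave open whether a longer chain on the carbonyl carbon, such as but-1-en-1-yl, or a chain carrying a dimethylamino group would move the number further. Among the compounds shown here, they also leave open whether the gain from prop-1-en-1-yl holds with 1-methyl-1H-pyrazol-3-yl on the nitrogen, since the only direct comparison of vinyl and prop-1-en-1-yl carries 3-methoxyphenyl.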